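The compounds below may be only part of what the source reports. "The series", "measured", "known", "first", "only" and "open" are said of these compounds alone.

Measured in a functional assay on A2780 cells (Homo sapiens) for inhibition, read by MTT assay, with a stated time of 72 h; on this read-out higher numbers stand for weaker inhibition and lower numbers for stronger inhibition:
- Compound 1 `O=C1/C(=C\c2ccccc2)c2c(ncn2COCc2ccccc2)CCN1Cc1ccccc1`: 20400 nM
- Compound 2 `O=C1/C(=C\c2ccccc2)c2c(ncn2COCc2ccccc2)CCN1Cc1ccc(F)cc1`: 24800 nM
- Compound 3 `Cc1cccc(CN2CCc3ncn(COCc4ccccc4)c3/C(=C/c3ccccc3)C2=O)c1`: 26300 nM

Going by the values given here, compound 2, at 24800 nM, sits in one tight group with the other two compounds, and no pair among them can be told apart. Compound 4 `COc1ccc(CN2CCc3ncn(COCc4ccccc4)c3/C(=C/c3ccccc3)C2=O)cc1` has not yet been measured. It carries methoxy in place of fluoro on an aromatic carbon, (methoxy in place of fluoro on an aromatic carbon).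

Among the compounds with values here, no measured pair makes this exact swap, so the nearest guides are other small changes on an aromatic carbon. Fluoro in place of hydrogen gave a 1.2-fold higher number from compound 1 to compound 2 (0.08 log units; within the scatter). Methyl in place of hydrogen gave a 1.3-fold higher number from compound 1 to compound 3 (0.11 log units; within the scatter). Exchanging the two substituted rings gave a 1.1-fold higher number from compound 2 to compound 3 (0.03 log units; within the scatter). All three steps are small, so no shift beyond the scatter is expected in this assay, and no direction can be favoured. The expected step is a 1.0-fold lower number from compound 2 to compound 4 (0.01 log units; within the scatter).

The estimated value for compound 4 is 24000 nM, with an expected range from 13000 nM to 42000 nM.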

Compound 4, half-maximal inhibitory concentration: 43100 nM
For compound 4 the middle estimate is 1.8-fold (0.25 log units) below the measured one; the whole stated range lies below it.
By their numbers in this assay, from the lowest: compounds 1, 2, 3 and 4 (each within the scatter of the next, the first and the last beyond it).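

In this assay, going by these compounds alone, methoxy on this aromatic carbon, para to a large group, gives a 2.1-fold higher number from compound 1 to compound 4 (0.32 log units; beyond the scatter) when set against the unsubstituted ring, and this is the first step at this position to pass the scatter, a modest loss of inhibition. Against the other substituted rings, the steps are a 1.7-fold higher number from compound 2 to compound 4 (0.24 log units; within the scatter) and a 1.6-fold higher number from compound 3 to compound 4 (0.21 log units; within the scatter) and leave methoxy unresolved from fluoro and from the 3-methylphenyl group, so only the comparison with hydrogen separates. Nothing shown here gives a measured reason for this modest step.

Still open, on these data alone, is whether a hydroxy group, an amine or a carboxylic acid on this same carbon would move the number further than methoxy does. Also open, as far as these compounds go, is whether methoxy elsewhere on this ring would give a similar step.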